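Hydrazone series: pyridin-3-yl in place of phenyl

This account rests on a few compounds, and the source may have more. Where it says the series, first, only, none or still open, it means among the compounds named here.

Compound 1 `COc1cc(/C=N\NC(=O)C2=C(Cl)c3cc(C)c(C)cc3CCC2)cc(OC)c1OC` gives 21000 nM in a functional assay on HeLa cells (Homo sapiens) for inhibition, read by sulforhodamine B assay, with a stated time of 48 h; a higher number here means a weaker inhibitor of growth, a lower number a stronger inhibitor of growth. Compound 2 `O=C(N/N=C/C1=C(Cl)c2ccccc2CCC1)c1ccccc1` reaches only a limit of this assay, > 100000 nM. That limit, (the limit of > 100000 nM in this assay, at which 1 of the 2 values shown sits), is where compound 2 stands; it cannot be placed as a number. Compound 3 `O=C(N/N=C/C1=C(Cl)c2ccccc2CCC1)c1cccnc1` carries pyridin-3-yl in place of phenyl on a carbonyl carbon. Going by the values given here, no measured pair bears on this change, so no step beyond the scatter is expected from it. Compound 3 is expected to sit near 100000 nM, with a range from 40000 nM to 300000 nM. The step this implies, a number no higher from compound 2 to compound 3 (the limit leaves the size open), is expected to be none beyond the scatter, so a limit again is likely.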

Compound 3, concentration for 50% growth inhibition: 7500 nM
Compound 3: middle estimate off by 13-fold (1.12 log units), on the high side; measured number outside the range, below it.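

Pyridin-3-yl in place of phenyl on a carbonyl carbon gives an at least 13-fold lower number from compound 2 to compound 3 (1.12 log units; beyond the scatter) in this assay. This first one-place pair shows that the group on this carbonyl carbon can shift growth inhibition beyond the scatter, with one ring nitrogen and its hydrogen-bond acceptor as the only counted differences. Compound 2 stands at a limit, so the full size of the step stays open: the limit of > 100000 nM in this assay, at which 1 of the 3 values shown sits.

The compounds shown leave open whether the ring nitrogen must sit as in pyridin-3-yl, or whether pyridin-4-yl or pyridin-2-yl would serve equally. Also open, as far as these compounds go, is whether the same exchange carries over to other cores.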